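The source may hold more compounds than are shown below. What is called first, only, known or untested is meant among the compounds shown, and "the series" means these compounds.

Compound 1 `O=C(/C=C/C1CCCCC1)c1ccccc1`, compound 2 `O=C(/C(=C/c1ccc(Cl)cc1Cl)CCl)c1ccccc1` and compound 3 `CC(=O)OC/C(=C\C1CCCCC1)C(=O)c1ccccc1` were tested in a functional assay on HeLa cells (Homo sapiens) for inhibition, read by sulforhodamine B assay, with a stated time of 48 h; a lower number here means a stronger inhibitor of growth, a higher number a weaker inhibitor of growth. Compound 1 gives 21000 nM, compound 2 gives 15000 nM and compound 3 gives 21000 nM. The three numbers lie within the usual scatter of each other, so none of these compounds can be called a stronger or weaker inhibitor than another: compound 3 shows the same digits as compound 1, and compound 2 sits close to both. Compound 4 `CC(=O)OC/C(=C\c1ccccc1Br)C(=O)c1ccccc1` has not yet been measured. It differs from compound 3 in one place: 2-bromophenyl in place of cyclohexyl on a double-bonded chain carbon bound to a double-bonded chain carbon. Because compound 2, which also carries an aromatic ring on the chain, gives 15000 nM, the estimated step of a 1.4-fold lower number from compound 3 to compound 4 (0.15 log units; within the scatter) is expected to stay within the scatter. Compound 4 is therefore expected to give about 15000 nM, in the range 6000 nM to 40000 nM.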

Compound 4, concentration for 50% growth inhibition: 20000 nM
Estimate against measurement, compound 4: 1.3-fold (0.12 log units) below, and the stated range covers the measured number.
By their numbers in this assay, from the lowest: compounds 2, 4, 1 and 3 (each within the scatter of the next).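

Replacing cyclohexyl with 2-bromophenyl on a double-bonded chain carbon bound to a double-bonded chain carbon gives a 1.1-fold lower number from compound 3 to compound 4 (0.02 log units; within the scatter) in this assay, so this read-out does not separate these two rings at this position. The earlier compounds shown here offered no such one-place comparison. No available evidence explains this result. Still open, on these data alone, is how an unsubstituted phenyl would compare, which would test the ring without the bromine. Also open, as far as these compounds go, is whether an amine, a carboxylic acid or a longer chain in this place would shift the number beyond the scatter.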